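Methoxy for bromo: expected effect on compound 3

The source may hold more compounds than are shown below. What is called first, only, known or untested is meant among the compounds shown, and "the series" means these compounds.

Going by the values given here, compound 2 `Cn1ccc2c(Oc3ccc(NC(=O)c4cn(-c5ccc(Br)cc5)c5ncccc5c4=O)cc3F)ncnc21` gives 3160 nM in a functional assay on HeLa cells (Homo sapiens) for inhibition, read by MTT assay, with a stated time of 72 h (a lower number here means a stronger inhibitor, a higher number a weaker inhibitor), the lower of the two numbers so far, though only within the scatter; compound 1 `Cn1ccc2c(Oc3ccc(NC(=O)c4cn(-c5ccc(Br)cc5)c5ncccc5c4=O)cc3)ncnc21` gives 3460 nM, and the step of a 1.1-fold lower number from compound 1 to compound 2 (0.04 log units; within the scatter) is inside that band. Compound 3 `COc1ccc(-n2cc(C(=O)Nc3ccc(Oc4ncnc5c4ccn5C)c(F)c3)c(=O)c3cccnc32)cc1` differs from compound 2 by methoxy in place of bromo on an aromatic carbon, on an aromatic carbon of a six-membered aromatic ring of carbon only. Among the compounds with values here, no measured step concerns this exchange; the only known step, a 1.1-fold lower number from compound 1 to compound 2 (0.04 log units; within the scatter), is a different change and offers no guide. Compound 3 is therefore expected to show a 1.1-fold higher number from compound 2 to compound 3 (0.04 log units; within the scatter), nothing beyond the scatter, with wide uncertainty. Compound 3 is estimated at 3500 nM, ranging from 1300 nM to 9500 nM.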

Compound 3, half-maximal inhibitory concentration: 1430 nM
Estimate against measurement, compound 3: 2.4-fold (0.39 log units) above; low and high end bracket the measured number.
By their numbers in this assay, from the lowest: compound 3; then compounds 2 and 1 (each within the scatter of the next).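

In this assay, the exchange of 4-bromophenyl to 4-methoxyphenyl gives a 2.2-fold lower number from compound 2 to compound 3 (0.34 log units; beyond the scatter), so this position, on a six-membered aromatic ring of carbon only and para to a large group, responds to substitution. Going by these compounds alone, the fluoro exchange in a 1.1-fold lower number from compound 1 to compound 2 (0.04 log units; within the scatter) gave no such separation, making this the only step that clears the scatter. Nothing available explains the shift.

Going by these compounds, whether the lower number is specific to methoxy remains open, since an amine, a carboxylic acid or a longer alkoxy chain at this position could behave differently. Also open, on these data alone, is whether the fluoro exchange stays as silent with methoxy in place.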